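This account rests on a few compounds, and the source may have more. Where it says the series, first, only, none or still open, it means among the compounds named here.

In a functional assay on OVCAR-3 cells (Homo sapiens) for antiproliferative activity, read by spectrophotometry, with a stated time of 2 days (on this read-out lower numbers stand for stronger inhibition of growth and higher numbers for weaker inhibition of growth), compound 1 `CN(c1cccc2c1CN(c1nc(Nc3cccc(Oc4ccccc4)c3)ncc1C(F)(F)F)C2)S(C)(=O)=O` gives 24900 nM. Compound 2 `Cc1ccc(Nc2ncc(C(F)(F)F)c(N3Cc4cccc(N(C)S(C)(=O)=O)c4C3)n2)c(C)c1` has the same core, but a different group on a nitrogen on an aromatic ring. In this assay, compound 2 is reported only as a limit, > 30000 nM, and not as a number. On these data alone, its true position therefore remains open, at the weak end of the values seen so far. Compound 3 `CN(c1cccc2c1CN(c1nc(Nc3cccc(C(F)(F)F)c3)ncc1C(F)(F)F)C2)S(C)(=O)=O` has 3-(trifluoromethyl)phenyl in place of 2,4-dimethylphenyl on a nitrogen on an aromatic ring, a change counted as 3-(trifluoromethyl)phenyl in place of 2,4-dimethylphenyl on a nitrogen on an aromatic ring. Going by the values given here, no measured step shows what such an exchange does. Among the compounds with values here, the only numerical guide is compound 1, at 24900 nM. A small shift towards stronger inhibition is expected, estimated as an at least 1.3-fold lower number from compound 2 to compound 3 (0.13 log units; that floor lies within the scatter), and another limit would not be surprising. Compound 3 is estimated at 22000 nM, with an expected range of 9000 nM to 40000 nM.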

Compound 3, concentration for 50% growth inhibition: > 30000 nM
Compound 3: a limit, no number; the forecaster's own chance of this, stated with the estimate: 35%; middle value at least 1.3-fold (0.13 log units) from the limit.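

In this assay compound 3 is also reported only as a limit, > 30000 nM. The step between the two limits cannot be read, so the exchange of 2,4-dimethylphenyl for 3-(trifluoromethyl)phenyl on this nitrogen has no size, and the values now gather at the top of the read-out: the limit of > 30000 nM in this assay, at which 2 of the 3 values shown sit. With trifluoromethyl in place of phenoxy on an aromatic carbon, the data give an at least 1.2-fold higher number from compound 1 to compound 3 (0.08 log units; that floor lies within the scatter), so this change is not shown to go beyond the scatter, though its true size may be larger.

The compounds shown do not tell whether any group at this place gives a clearly stronger inhibition of growth. On these data alone, what an amine or a carboxylic acid on the phenyl ring would do remains open.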